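The source may hold more compounds than are shown below. What is called first, only, known or untested is meant among the compounds shown, and "the series" means these compounds.

Working notes on the series. Compound 1 `CCc1ccccc1OS(=O)(=O)c1ccc(N2CCN(C)C2=O)cc1` in a functional assay on M21 cells (Homo sapiens) for antiproliferative activity, read by sulforhodamine B assay, with a stated time of 48 h (a lower number here means a stronger inhibitor, a higher number a weaker inhibitor), gives 2300 nM. Compound 2 `CCN1CCN(c2ccc(S(=O)(=O)Oc3ccccc3OC)cc2)C1=O` in this assay reaches only a limit of the assay, > 100000 nM. Compound 3 `CCCN1CCN(c2ccc(S(=O)(=O)Oc3ccccc3CC)cc2)C1=O` in this assay likewise returns only a limit, > 50000 nM. The one step that can be read, an at least 21-fold higher number from compound 1 to compound 3 (1.33 log units; beyond the scatter), places compound 3 at the weak end of the numbers shown; the limit at the limit of > 50000 nM in this assay, at which 1 of the 3 values shown sits, is where compound 3 sits, and compound 2 sits at the limit (the limit of > 100000 nM in this assay, at which 1 of the 3 values shown sits). Compound 1 and compound 2 differ in two places, so their values are only compared, not read as a step.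

Compound 4 `CCCN1CCN(c2ccc(S(=O)(=O)Oc3ccc(F)cc3)cc2)C1=O` follows from compound 3 by 4-fluorophenyl in place of 2-ethylphenyl on an oxygen. Within the data shown here, no measured step touches the group on the oxygen; the only measured step concerns the ring nitrogen and does not bear on this change. With compound 3 already at a limit, the direction of any change cannot be read from the numbers. Compound 4 is therefore expected near 50000 nM, within 8000 nM to 150000 nM. The step of a number no higher from compound 3 to compound 4 (the limit leaves the size open) is expected to stay within the scatter, with a fair chance that only a limit is reported.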

Compound 4, half-maximal inhibitory concentration: 14000 nM
Compound 4: the middle estimate sits 3.6-fold (0.55 log units) above what was measured, and the stated range covers the measured number.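

Replacing 2-ethylphenyl with 4-fluorophenyl on the oxygen bound to the sulfonyl sulfur gives an at least 3.5-fold lower number from compound 3 to compound 4 (0.55 log units; beyond the scatter) in this assay, so the group at this position does shift the read-out. As far as these compounds go, the value of compound 3 (> 50000 nM) is a limit of the assay, so the direction of the step is fixed while its full size stays open. The earlier compounds gave a readable step only at the ring nitrogen, and nothing shown accounts for this new shift at the oxygen.

The compounds shown cannot separate the loss of the ethyl from the arrival of the fluorine, as both change together in this one step. Also open, from the compounds shown here alone, is how an amine or a carboxylic acid on that aromatic ring, or a longer chain on the ring nitrogen, would read in this assay alongside compound 4.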